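Replacing the pentylamide of compound 2 with a pyrrolidine amide

The source may report more compounds than this note shows. Statements on the series, on what has been measured and on what is new or still open speak of the compounds shown alone.

Measured so far:
compound 1, `CCCNC(=O)CC1CCc2cc(OC)c(OC)cc21`: 18.8%
compound 2, `CCCCCNC(=O)CC1CCc2cc(OC)c(OC)cc21`: 34.4%

In a functional assay on the whole organism (strain Wistar) for inhibition, with Rattus norvegicus as the target, read by paw edema, with stated times of 60 min and 1 h, at a dose of 100 mg/kg by the oral route (on this read-out lower numbers stand for less inhibition and higher numbers for more inhibition at the one dose given (going by the name of the read-out)), compound 2 stands highest of the two numbers measured. Its nearest neighbour is compound 1, and the step of a number 15.6 percentage points higher from compound 1 to compound 2 (beyond the scatter) arises from ethyl in place of hydrogen on a saturated chain carbon, three bonds along the chain from an amide-type nitrogen. Compound 3, `COc1cc2c(cc1OC)C(CC(=O)N1CCCC1)CC2`, awaits measurement in this assay. It differs from compound 2 by pyrrolidin-1-yl in place of pentylamino on a carbonyl carbon. For the measured compounds named here, no measured step covers a change of this kind: the one known step keeps the amide hydrogen and only alters the chain, whereas compound 3 brings in a five-membered non-aromatic ring with no hydrogen-bond donor. That one step was modest, so a step of similar or smaller size is expected here, with the direction open. Compound 3 is therefore expected near 26%, within 8% to 44%, an estimated step of a number 8.4 percentage points lower from compound 2 to compound 3 (within the scatter).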

Compound 3, a percentage reported as inhibition, in the whole organism at one dose (the size of the read-out at that dose, not a potency): 4.69%
For compound 3 the middle estimate is 21.3 percentage points above the measured one, outside the stated range (below it).
By their numbers in this assay, from the lowest: compound 3; then compound 1; then compound 2.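

In this assay, pyrrolidin-1-yl on the carbonyl carbon gives a number 29.7 percentage points lower from compound 2 to compound 3 (beyond the scatter) when it takes the place of pentylamino, and a number 14.1 percentage points lower from compound 1 to compound 3 (beyond the scatter) when it takes the place of propylamino. The earlier pair varied only the chain and kept the amide hydrogen, whereas here the entering group carries a five-membered non-aromatic ring and no hydrogen-bond donor, and the number falls against both chains. No measurement available here separates the loss of the donor from the arrival of the ring as the source of this fall.

Going by these compounds, it remains open how a dimethylamino group, which also lacks the amide hydrogen but has no ring, would read at this carbonyl carbon. Also open, on these data alone, are the effects of a piperidin-1-yl ring and of a chain longer than pentylamino.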